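Shortening a chain on the shared core

The source may hold more compounds than are shown below. What is called first, only, known or untested is meant among the compounds shown, and "the series" means these compounds.

Measured compounds and their inhibition values:
compound 1, `O=C(CI)NCCCCC(=O)NCCCCCCNc1ncnc2c1ncn2[C@@H]1O[C@H](COP(=O)(O)OP(=O)(O)OP(=O)(O)O)[C@@H](O)[C@H]1O`, 0%
compound 2, `Nc1ncnc2c1nc(NCCCCNC(=O)CI)n2[C@@H]1O[C@H](COP(=O)(O)OP(=O)(O)OP(=O)(O)O)[C@@H](O)[C@H]1O`, 0%
compound 3, `O=C(CI)NCCCNc1ncnc2c1ncn2[C@@H]1O[C@H](COP(=O)(O)OP(=O)(O)OP(=O)(O)O)[C@@H](O)[C@H]1O`, 0%

In an assay on isolated protein for inhibition of hexokinase-3 (Rattus norvegicus), with a stated time of 6 h, tested at 10 mM (a lower number here means less inhibition, a higher number more inhibition at the concentration tested (going by the name of the read-out)), compound 2 gives 0%. On the digits reported, compound 2 is level with compound 1 and with compound 3: none of the three shows inhibition beyond the scatter, so the inhibition in this assay can be called neither higher nor lower for any one of them than for another. The three compounds all carry the same core with a tail ending in an iodomethyl carbonyl, and they differ only in where that tail is attached and in how long it is.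

Compound 4, `Nc1ncnc2c1nc(NCCNC(=O)CI)n2[C@@H]1O[C@H](COP(=O)(O)OP(=O)(O)OP(=O)(O)O)[C@@H](O)[C@H]1O`, has not yet been measured. It differs from compound 2 in one place: ((iodomethyl)carbonyl)amino in place of 2-(((iodomethyl)carbonyl)amino)ethyl on a saturated chain carbon, two bonds along the chain from a nitrogen on an aromatic ring. The tail that leaves is 2-(((iodomethyl)carbonyl)amino)ethyl, and what enters in its place is ((iodomethyl)carbonyl)amino, so the tail is shorter by the counted atoms, on a saturated chain carbon two bonds along the chain from a nitrogen on an aromatic ring.

Given that compound 1, compound 2 and compound 3 all sit at the bottom of the scale in this assay, no step beyond the scatter is expected from compound 2 to compound 4, a number 2 percentage points higher from compound 2 to compound 4 (within the scatter). For compound 4 the expected value is 2%, with a likely range from 0% to 12%.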

Compound 4, a percentage reported as inhibition, at one concentration (the size of the read-out at that concentration, not a potency): 0%
Compound 4: the middle estimate sits 2 percentage points above what was measured; the measured number falls inside the stated range.
By their numbers in this assay, from the lowest: compounds 1, 2, 3 and 4 (each within the scatter of the next).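

In this assay, putting ((iodomethyl)carbonyl)amino in place of 2-(((iodomethyl)carbonyl)amino)ethyl on a saturated chain carbon, two bonds along the chain from a nitrogen on an aromatic ring, gives no change at the digits printed from compound 2 to compound 4 (within the scatter). This is the first pair shown that differs in one place, so the effect of shortening the chain at this position can be read directly, and the shorter chain brings no inhibition into view. Since both compounds sit at the bottom of the scale, the step shows only that neither chain length gives a readable signal at the concentration tested, and no measurement shown offers a reason for this.

Still open, from the compounds shown here alone, is whether a longer chain at this position would produce any inhibition, or whether an amine or a carboxylic acid in place of the iodomethyl carbonyl end would do so. With every compound shown level at the bottom of the scale, the compounds also leave open whether the shared core can give a measurable signal in this assay with any tail at all.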